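From propyl to phenyl at the cytotoxicity limit

The source may report more compounds than this note shows. Statements on the series, on what has been measured and on what is new or still open speak of the compounds shown alone.

Compound 1 `CC1=C(C(=O)OCC2CCCCC2)C(c2cccc(O)c2)N(C)C(=O)N1` and compound 2 `CCCC1=C(C(=O)OCC2CCCCC2)C(c2cccc(O)c2)NC(=O)N1` share a core and were both tested in an ADME assay on CEMx174 cells (Homo sapiens) for cytotoxicity; a higher number here means that more compound is tolerated, a lower number that less compound is tolerated. Compound 1 gives > 10000 nM, which is a limit and not a number. Compound 2 gives > 10000 nM, also a limit, and so stands at the limit of > 10000 nM in this assay, at which 2 of the 2 values shown sit. Compound 3 `O=C1NC(c2ccccc2)=C(C(=O)OCC2CCCCC2)C(c2cccc(O)c2)N1` carries phenyl in place of propyl on a double-bonded ring carbon. For the measured compounds named here, no measured step covers this change, and no shift beyond the scatter is expected in this assay, in either direction. The expected step is a step that the limit leaves unreadable from compound 2 to compound 3. Compound 3 is estimated at 15000 nM, with an expected range from 6000 nM to 40000 nM.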

Compound 3, half-maximal cytotoxic concentration: > 10000 nM
Compound 3 ended at the assay's limit; the forecaster's own chance of this, stated with the estimate: 75%; the middle value does not contradict the limit.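

Compound 2 and compound 3 both stand at a limit in this assay, so the change from propyl to phenyl gives no readable step. The compounds shown leave open at what concentration each becomes cytotoxic.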